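The source may report more compounds than this note shows. Statements on the series, on what has been measured and on what is new or still open speak of the compounds shown alone.

Compound 1 `Cc1ccc(NC(=O)c2cccc(/C=C3\CC(=O)N(c4ccccc4)C3=O)c2)cc1` carries a methyl group on an aromatic carbon. In an ADME assay on HCT-116 cells (Homo sapiens) for cytotoxicity, read by MTT assay, with a stated time of 72 h (a lower number here means a stronger inhibitor, a higher number a weaker inhibitor), compound 1 gives only the limit > 100000 nM, not a number. Compound 2 `COc1ccc(NC(=O)c2cccc(/C=C3\CC(=O)N(c4ccccc4)C3=O)c2)cc1` has methoxy in place of that methyl. In this assay compound 2 likewise gives only the limit > 100000 nM. The step that the two limits leave unreadable from compound 1 to compound 2 cannot be read in size, since (the limit of > 100000 nM in this assay, at which 2 of the 2 values shown sit). Compound 2 thus stands at the limit, with no measured number to place it more exactly. Compound 3 `O=C(NCc1ccccc1)c1cccc(/C=C2\CC(=O)N(c3ccccc3)C2=O)c1` differs from compound 2 by benzyl in place of 4-methoxyphenyl on an amide-type nitrogen. Within the data shown here, the single measured step bears on this change only in that neither of its ends reached a readable number, so no size or direction can be drawn from it; the expected step of a number no higher from compound 2 to compound 3 (the limit leaves the size open) in this assay therefore rests on two limits alone. The estimate for compound 3 in this assay is 100000 nM, within a range from 30000 nM to 300000 nM, with a limit again the most likely report.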

Compound 3, half-maximal inhibitory concentration: > 100000 nM
Compound 3: only a limit was reported; the forecaster's own chance of this, stated with the estimate: 75%; the middle value sits exactly at the limit.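

In this assay compound 3 gives > 100000 nM, a limit and not a number. Among these compounds, no step among compound 1, compound 2 and compound 3 can be read, in size or in direction: the limit of > 100000 nM in this assay, at which 3 of the 3 values shown sit. The compounds shown leave open whether changing the group on the amide-type nitrogen alters cytotoxicity in this assay at all.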